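Side-chain variation on the ring nitrogen: compound 3 to compound 4

The source may hold more compounds than are shown below. What is called first, only, known or untested is meant among the compounds shown, and "the series" means these compounds.

Three members of the series differ only in the chain carried on the ring nitrogen. In an assay on isolated protein for inhibition of Indoleamine 2,3-dioxygenase 1 (Homo sapiens), read by fluorescence, with a stated time of 60 min (a higher number here means a weaker inhibitor, a lower number a stronger inhibitor), compound 1 `C#CCNS(=O)(=O)CCNc1nonc1/C(=N/O)Nc1ccc(F)c(Br)c1` gives 218 nM, compound 2 `NNS(=O)(=O)CCNc1nonc1/C(=N/O)Nc1ccc(F)c(Br)c1` gives 135 nM and compound 3 `CN(C)S(=O)(=O)CCCNc1nonc1/C(=N/O)Nc1ccc(F)c(Br)c1` gives 97 nM. Compound 3 shows the lowest of the three numbers, but a 1.4-fold lower number from compound 2 to compound 3 (0.14 log units; within the scatter), and only a 2.2-fold lower number from compound 1 to compound 3 (0.35 log units; beyond the scatter).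

Compound 4 `NS(=O)(=O)CCONc1nonc1/C(=N/O)Nc1ccc(F)c(Br)c1` brings (2-sulfamoylethoxy in place of 3-(dimethylsulfamoyl)propyl on a nitrogen on an aromatic ring). The measured steps of a 1.6-fold lower number from compound 1 to compound 2 (0.21 log units; within the scatter) and a 2.2-fold lower number from compound 1 to compound 3 (0.35 log units; beyond the scatter) only exchanged the group on the sulfonamide nitrogen or shortened the chain; none put an oxygen into the chain. Their sizes suggest a small step, so the expected outcome is a 1.5-fold higher number from compound 3 to compound 4 (0.19 log units; within the scatter). Compound 4 is therefore estimated at 150 nM, within 60 nM to 400 nM in this assay.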

Compound 4, half-maximal inhibitory concentration: 87 nM
Compound 4: middle estimate off by 1.7-fold (0.24 log units), on the high side, and the stated range covers the measured number.
By their numbers in this assay, from the lowest: compounds 4, 3, 2 and 1 (each within the scatter of the next, the first and the last beyond it).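

With 2-sulfamoylethoxy on the nitrogen on an aromatic ring, this assay shows a 1.1-fold lower number from compound 3 to compound 4 (0.05 log units; within the scatter) and a 1.6-fold lower number from compound 2 to compound 4 (0.19 log units; within the scatter), so a chain oxygen and an unsubstituted sulfonamide nitrogen together leave the number within the scatter of both compounds. Only the comparison with the propargyl-bearing compound goes beyond the scatter (a 2.5-fold lower number from compound 1 to compound 4 (0.40 log units; beyond the scatter)). No measured evidence accounts for this result.

The chain oxygen and the sulfonamide nitrogen change together here, so their contributions cannot be separated. As far as these compounds go, a carboxylic acid in place of the sulfonamide, or a longer chain carrying the oxygen, remains open.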